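The source may report more compounds than this note shows. Statements on the series, on what has been measured and on what is new or still open speak of the compounds shown alone.

Measured compounds:
compound 1, `COc1c(C)nc2c(CCc3ccccc3)cccn12`, 0%
compound 2, `Cc1nc2c(CCc3ccccc3)cccn2c1O`, 0%

In a functional assay on the whole organism with Canis familiaris (Canis lupus familiaris) as the target, at a dose of 2 mg/kg by the intravenous route (a lower number here means a weaker effect, a higher number a stronger effect of the compound at the dose given), compound 1 gives 0%. Compound 2, in this assay, gives 0%. Within the data shown here, the single measured step, no change at the digits printed from compound 1 to compound 2 (within the scatter), exchanges hydrogen for methyl on an oxygen on an aromatic ring and leaves the read-out where it was. Compound 2 therefore stands level with compound 1 at the digits shown, and its nearest neighbour is compound 1, with no change within the scatter.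

Compound 3, `COC(=O)c1c(C)nc2c(CCc3ccccc3)cccn12`, is not yet measured. It differs from compound 2 by methoxycarbonyl in place of hydroxy on an aromatic carbon. Among the measured compounds shown here, the one step available touches the same oxygen-bearing position, but it only swaps hydrogen and methyl there, whereas here the hydroxy leaves altogether and a methoxycarbonyl enters. That step was flat, and nothing measured here points to any movement, so no change beyond the scatter is expected for compound 3, a step of no change at the digits printed from compound 2 to compound 3 (within the scatter). Compound 3 is accordingly estimated at 0% in this assay, with a range from 0% to 20%.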

Compound 3, a percentage reported as inhibition, in the whole organism at one dose (the size of the read-out at that dose, not a potency): 6%
For compound 3 the middle estimate is 6 percentage points below the measured one; the range from low to high includes it.
By their numbers in this assay, from the lowest: compounds 1, 2 and 3 (each within the scatter of the next).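

In this assay, the step from an oxygen-linked group to a carbonyl-linked one on this aromatic carbon gives a number 6 percentage points higher from compound 2 to compound 3 (within the scatter) and, set against the methoxy group, a number 6 percentage points higher from compound 1 to compound 3 (within the scatter). Until now the position had only been probed by exchanging hydrogen and methyl on the same oxygen, whereas compound 3 replaces that oxygen substituent altogether with methoxycarbonyl, a larger group with no hydrogen-bond donor, and still cannot be told apart from compound 1 or compound 2. The data therefore show that neither the size of the group nor the atom joined to the ring separates these three compounds at this dose, and nothing available explains the read-outs.

All three read-outs lie near the bottom of the scale, so the compounds shown leave open whether any group on this aromatic carbon can produce a clear effect at this dose. A carboxylic acid, a primary amide or an aminomethyl group at this place, or a longer chain in place of the methyl of the methoxycarbonyl group, might read differently, and these three compounds give no indication either way.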